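Amino in Place of Carbamoyl: Expecting Compound 4

The source may report more compounds than this note shows. Statements on the series, on what has been measured and on what is new or still open speak of the compounds shown alone.

Compound 1 `NC(=O)c1cccc(CCCCCC(=O)N2CCOC2=O)c1` in an assay on HEK293 cells for inhibition of N-acylethanolamine-hydrolyzing acid amidase (Rattus norvegicus), read by LC-MS, with a stated time of 30 min (on this read-out higher numbers stand for weaker inhibition and lower numbers for stronger inhibition), gives > 20000 nM, a limit of the assay.
Compound 2 `Nc1cccc(CCCCCC(=O)N2CCOC2=O)c1` in this assay gives > 20000 nM, again a limit.
Compound 3 `NC(=O)c1ccc(CCCCCC(=O)N2CCOC2=O)cc1` in this assay gives > 20000 nM, also a limit.

All three measured compounds share the same chain ending in the same amide, and differ only in the group on the aromatic ring and where it sits. The change from compound 1 to compound 2 is amino in place of carbamoyl on an aromatic carbon. Its step, a step that the two limits leave unreadable from compound 1 to compound 2, cannot be read, because the limit of > 20000 nM in this assay, at which 3 of the 3 values shown sit, hides whatever difference there may be. The difference between the core of compound 1 and the core of compound 3 is not broken down here.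

Compound 4 `Nc1ccc(CCCCCC(=O)N2CCOC2=O)cc1` is not yet measured. Going from compound 3 to compound 4 makes (amino in place of carbamoyl on an aromatic carbon). Among the measured compounds shown here, this is the same kind of change as the one from compound 1 to compound 2, but not the same: there the amino sits meta to a large group, here para to a large group.

For the measured compounds named here, with every value so far sitting at the limit, the only guide is that the same kind of change left compound 1 and compound 2 both at the limit, as a step that the two limits leave unreadable from compound 1 to compound 2 shows. The expected step is therefore a step that the limit leaves unreadable from compound 3 to compound 4. Compound 4 is expected to give about 30000 nM, most likely reported again only as a limit. The expected range for compound 4 runs from 8000 nM to 120000 nM.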

Compound 4, half-maximal inhibitory concentration: 15700 nM
Estimate against measurement, compound 4: 1.9-fold (0.28 log units) above; the measured number falls inside the stated range.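

Placed on the core of compound 3, amino in place of carbamoyl gives an at least 1.2-fold lower number from compound 3 to compound 4 (0.10 log units; that floor lies within the scatter) in this assay; that figure is only a floor, so the true step may be larger, but the data do not establish that it is, and compound 4 is the only compound here with a number rather than a limit. The core of compound 1 carries the same change in compound 2, which gives > 20000 nM, a limit of the assay. The step between the two compounds on that other core cannot be read, and so these data show neither that the change carries across cores nor that it fails to, because both values there sit at the limit: the limit of > 20000 nM in this assay, at which 3 of the 4 values shown sit.

The compounds shown leave open whether another group at the same place on the ring, such as a carboxylic acid, a hydroxyl or a methylamino group, would give a number further from the limit than amino does. They also leave open how a longer or a shorter chain between the ring and the shared end of the molecule would read in this assay, with amino kept in place.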